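Swapping a nitrile for a benzoyl on the triazole aryl

The compounds below may be only part of what the source reports. "The series", "measured", "known", "first", "only" and "open" are said of these compounds alone.

Compound 1 `C=CCc1ccc(OCc2cn(-c3ccc(C#N)cc3)nn2)c(O)c1` was tested in a functional assay on MIA PaCa-2 cells (Homo sapiens) for inhibition, read by MTT assay, with a stated time of 72 h, tested at 50 uM (a higher number here means more inhibition of growth at the concentration tested, a lower number less inhibition of growth), and gives 45.9%. Its two measured relatives share the same core: compound 2 `C=CCc1ccc(OCc2cn(-c3ccccc3CO)nn2)c(O)c1` gives 52.1% and compound 3 `C=CCc1ccc(OCc2cn(-c3cccc(C#N)c3)nn2)c(O)c1` gives 41.6%, so compound 1 sits within the scatter of both of them.

Compound 4 `C=CCc1ccc(OCc2cn(-c3ccc(C(=O)c4ccccc4)cc3)nn2)c(O)c1` has not yet been measured. Relative to compound 1 the change is benzoyl in place of cyano on an aromatic carbon. Within the data shown here, no measured step exchanges this particular group, so the nearest guides are the other changes on the same aryl ring: a number 6.2 percentage points higher from compound 1 to compound 2 (within the scatter) and a number 4.3 percentage points lower from compound 1 to compound 3 (within the scatter), while a number 10.5 percentage points lower from compound 2 to compound 3 (beyond the scatter). Every alteration on this ring so far has moved the result only a little. A step of similar scale, in either direction or none beyond the scatter, is therefore expected for a number 2.1 percentage points higher from compound 1 to compound 4 (within the scatter).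

On this basis compound 4 is estimated to give 48%, with a likely span from 30% to 66%.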

Compound 4, percent growth inhibition at one concentration: 53.7%
The estimate for compound 4 lay 5.7 percentage points below the measured number, and the stated range covers the measured number.
By their numbers in this assay, from the lowest: compounds 3, 1, 2 and 4 (each within the scatter of the next, the first and the last beyond it).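

In this assay, benzoyl in place of the nitrile gives a number 7.8 percentage points higher from compound 1 to compound 4 (within the scatter), so a much larger group, one that brings a whole extra six-membered aromatic ring, leaves the result within the scatter of compound 1. The earlier compounds shown here only moved the nitrile or exchanged it for a hydroxymethyl group on the ring, whereas compound 4 shows that this position also accepts a far bulkier substituent with no clear change in growth inhibition. No supporting measurement is available to explain why the size of the group matters so little here.

On these data alone, it remains open whether an amine or a carboxylic acid at this same position would also leave the result unchanged. A single test concentration also leaves open how compound 4 and compound 1 would compare across a range of concentrations.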